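Swapping the Indole for a Trifluoromethylphenyl

This account rests on a few compounds, and the source may have more. Where it says the series, first, only, none or still open, it means among the compounds named here.

Compound 1 `COc1cc(-c2ccnc3cc(-c4ccc5cc[nH]c5c4)nn23)cc(OC)c1OC` gives 170 nM in a functional assay on A549 cells (Homo sapiens) for inhibition, read by CCK-8 assay, with a stated time of 48 h (on this read-out higher numbers stand for weaker inhibition and lower numbers for stronger inhibition), the lowest of the numbers measured here. Compound 2 `COc1cc(-c2ccnc3cc(-c4ccc(C(C)=O)cc4)nn23)cc(OC)c1OC` gives 4100 nM in this assay. Compound 3 `COc1cc(-c2ccnc3cc(-c4cccc(C#N)c4)nn23)cc(OC)c1OC` reaches only a limit of this assay, > 10000 nM. The unmeasured compound 4 `COc1cc(-c2ccnc3cc(-c4ccc(C(F)(F)F)cc4)nn23)cc(OC)c1OC` differs from compound 1 by 4-(trifluoromethyl)phenyl in place of 1H-indol-6-yl on an aromatic carbon. Among the measured compounds shown here, two measured steps bear on this change, since each also replaces the indolyl group with a substituted phenyl: a 24-fold higher number from compound 1 to compound 2 (1.38 log units; beyond the scatter) and an at least 58-fold higher number from compound 1 to compound 3 (1.76 log units; beyond the scatter), both large losses of inhibition. A large rise in this assay is therefore expected for compound 4, a step of about a 29-fold higher number from compound 1 to compound 4 (1.47 log units; beyond the scatter). Compound 4 is estimated at 5000 nM, with a range from 1500 nM to 15000 nM, and a real chance that only a limit is reported.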

Compound 4, half-maximal inhibitory concentration: 2070 nM
For compound 4 the middle estimate is 2.4-fold (0.38 log units) above the measured one; measured number inside the range.
By their numbers in this assay, from the lowest: compound 1; then compounds 4 and 2 (each within the scatter of the next). At a limit, above all of these: compound 3.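

A third substituted phenyl also falls short of the indolyl group at this position, with a 12-fold higher number from compound 1 to compound 4 (1.09 log units; beyond the scatter) in a change that removes the five-membered ring and the hydrogen-bond donor. The group on the phenyl still matters in part: trifluoromethyl and acetyl cannot be told apart, with a 2.0-fold lower number from compound 2 to compound 4 (0.30 log units; within the scatter) here, yet 4-(trifluoromethyl)phenyl does better than 3-cyanophenyl, with an at least 4.8-fold lower number from compound 3 to compound 4 (0.68 log units; beyond the scatter) as a step that starts from a limit. Compound 3 sits at that limit: the limit of > 10000 nM in this assay, at which 1 of the 4 values shown sits.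

Still open, on these data alone, is whether a phenyl carrying an amine or a hydroxyl group, each with a hydrogen-bond donor, would regain the inhibition of compound 1. The compounds shown also cannot separate the part played by that donor from the part played by the second ring.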